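This account rests on a few compounds, and the source may have more. Where it says the series, first, only, none or still open, it means among the compounds named here.

Measured in a functional assay on A549 cells (Homo sapiens) for antiproliferative activity, read by MTT assay, with a stated time of 48 h; a higher number here means a weaker inhibitor, a lower number a stronger inhibitor:
- Compound 1 `COc1cc(-c2nnc3c(OCC(F)(F)F)cc(-c4ccc5[nH]ccc5c4)cn23)cc(OC)c1OC`: 585 nM
- Compound 2 `COc1cc(-c2nnc3c(OC4CC4)cc(-c4ccc5[nH]ccc5c4)cn23)cc(OC)c1OC`: 198 nM

Compound 2 holds the lower of the two numbers, at 198 nM, and so is the stronger inhibitor of this pair. Compound 3 `COc1cc(-c2nnc3c(OC4CC4)cc(-c4ccc5c(ccn5C)c4)cn23)cc(OC)c1OC` departs from compound 2 in one place: methyl in place of hydrogen on an aromatic nitrogen. This is methyl in place of hydrogen on an aromatic nitrogen, turning 1H-indol-5-yl into 1-methyl-1H-indol-5-yl.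

Within the data shown here, only one measured step exists, a 3.0-fold lower number from compound 1 to compound 2 (0.47 log units; beyond the scatter). It is modest but beyond the scatter, and it replaces 2,2,2-trifluoroethyl with cyclopropyl on an oxygen on an aromatic ring, elsewhere in the molecule. Among the measured compounds shown here, it therefore bears only indirectly on the new change, and no measured compound carries this methyl. With so little evidence, no step beyond the scatter is expected in this assay, and no direction is firmly favoured. The expected step is small: a 1.2-fold lower number from compound 2 to compound 3 (0.07 log units; within the scatter). For compound 3 the estimated value is 170 nM, with an expected range of 55 nM to 560 nM.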

Compound 3, half-maximal inhibitory concentration: 168 nM
Compound 3: the middle estimate sits 1.0-fold (0.01 log units) above what was measured; low and high end bracket the measured number.
By their numbers in this assay, from the lowest: compounds 3 and 2 (each within the scatter of the next); then compound 1.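

In this assay, the step is a 1.2-fold lower number from compound 2 to compound 3 (0.07 log units; within the scatter), so the two compounds cannot be told apart, and turning 1H-indol-5-yl into 1-methyl-1H-indol-5-yl leaves the reading inside the usual scatter. Among these compounds, this is the first information about the aromatic nitrogen of this five-membered ring: the earlier pair varied only the group on the oxygen and kept the hydrogen on that nitrogen throughout. The result shows that, with cyclopropyl on the oxygen, the hydrogen on this nitrogen can be replaced by methyl without a step beyond the scatter, although no evidence is available that would explain this outcome.

Whether methyl is tolerated just as well alongside the 2,2,2-trifluoroethyl group of compound 1 remains an open question, as the pairing of that group with 1-methyl-1H-indol-5-yl is absent from the compounds shown. From the compounds shown here alone, it is also open how far this tolerance extends on the nitrogen, for instance to an ethyl group, a longer chain ending in an amine, or an acetyl group.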